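Sulfamoyl in place of carbamoyl on the aryl ring

The compounds below may be only part of what the source reports. "The series", "measured", "known", "first", "only" and "open" are said of these compounds alone.

Measured so far:
- Compound 1 `CC(C)S(=O)(=O)c1ccc(S(=O)(=O)N2CCC[C@@H](C(=O)N3CCC(F)(F)CC3)C2)cc1`: in a functional assay on MIA PaCa-2 cells (Homo sapiens) for inhibition, read by MTT assay, with a stated time of 7 days (on this read-out higher numbers stand for weaker inhibition and lower numbers for stronger inhibition), compound 1 gives 11 nM.
- Compound 2 `CCN(CC)C(=O)c1ccc(S(=O)(=O)N2CCC[C@@H](C(=O)N3CCC(F)(F)CC3)C2)cc1`: in this assay compound 2 gives 70 nM.

Compound 2 stands at the higher of the two numbers; its nearest neighbour is compound 1, separated by a 6.4-fold higher number from compound 1 to compound 2 (0.80 log units; beyond the scatter). Compound 3 `CN(C)S(=O)(=O)c1ccc(S(=O)(=O)N2CCC[C@@H](C(=O)N3CCC(F)(F)CC3)C2)cc1` differs from compound 2 by dimethylsulfamoyl in place of diethylcarbamoyl on an aromatic carbon. Going by the values given here, only that one step bears on this change; it was modest yet beyond the scatter, and compound 3 returns to a sulfonyl-type group like that of compound 1, so a partial recovery is expected, a 3.2-fold lower number from compound 2 to compound 3 (0.50 log units; beyond the scatter) in this assay. Compound 3 is estimated at 22 nM, expected between 8 nM and 60 nM.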

Compound 3, half-maximal inhibitory concentration: 118 nM
The estimate for compound 3 lay 5.4-fold (0.73 log units) below the measured number; the measured number lies above the stated range.
By their numbers in this assay, from the lowest: compound 1; then compounds 2 and 3 (each within the scatter of the next).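

A step of a 1.7-fold higher number from compound 2 to compound 3 (0.23 log units; within the scatter) in this assay leaves dimethylsulfamoyl and diethylcarbamoyl on this aromatic carbon indistinguishable. A sulfonyl on the ring is therefore not enough to match compound 1, since the step of an 11-fold higher number from compound 1 to compound 3 (1.03 log units; beyond the scatter) shows that the group on the sulfonyl sulfur matters in this pair, with dimethylamino in place of isopropyl. No available measurement accounts for this difference. On these data alone, whether methylsulfonyl, cyclopropylsulfonyl or an unsubstituted sulfamoyl on the same carbon would read like compound 1 or like compounds 2 and 3 remains open.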